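Amide to ester at the end of the propanoyl chain

A few compounds are considered here, and "the series" means these few. Any claim that something is new, unique, unknown or untested is made for them only; others in the source may bear on it.

Compound 2 `CNC(=O)CCc1ccncc1-c1ccc2ccccc2c1` and compound 1 `NNC(=O)CCc1ccncc1-c1ccc2ccccc2c1` share one core and differ only on the amide nitrogen. For the measured compounds named here, in an assay on a protein complex for inhibition of CDK8/Cyclin C (Homo sapiens), with a stated time of 1 h, tested at 10 uM (a lower number here means less inhibition, a higher number more inhibition at the concentration tested (going by the name of the read-out)), compound 1 gives 102%, and compound 2 gives 100%; the step of a number 2 percentage points lower from compound 1 to compound 2 (within the scatter) lies within the scatter, so compound 2 stands, with compound 1 as its only neighbour, at a level the scatter does not separate, both at the top of the read-out. Compound 3 `COC(=O)CCc1ccncc1-c1ccc2ccccc2c1` is the next step: methoxy in place of methylamino on a carbonyl carbon. Going by the values given here, only the step from compound 1 to compound 2 touches the same end of the chain; it was within the scatter, yet it kept the amide hydrogen, which compound 3 does not, and no measured pair shows what that change does. The expectation for compound 3 in this assay is a step of a number 12 percentage points lower from compound 2 to compound 3 (beyond the scatter), downward if anything, possibly beyond the scatter. Compound 3 is estimated at 88%, within 55% to 102%.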

Compound 3, a percentage reported as inhibition, at one concentration (the size of the read-out at that concentration, not a potency): 98%
The estimate for compound 3 lay 10 percentage points below the measured number, and the stated range covers the measured number.
By their numbers in this assay, from the lowest: compounds 3, 2 and 1 (each within the scatter of the next).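

Methoxy in place of methylamino on a carbonyl carbon takes away the amide hydrogen, and in this assay this gives a number 2 percentage points lower from compound 2 to compound 3 (within the scatter) and, with aminoamino as the group replaced, a number 4 percentage points lower from compound 1 to compound 3 (within the scatter) as well. At this position, then, the amide hydrogen is not needed to hold the read-out at the one concentration tested, and the ester cannot be told apart from either amide-type group. Nothing available explains this result.

All three compounds stand at the top of a single-concentration read-out that is not a potency, so differences in potency among them could stay hidden. As far as these compounds go, how a carboxylic acid, a dimethylamide or a longer chain would read at this end of the 2-(methoxycarbonyl)ethyl group remains open.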